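Cytotoxicity series: nitro to trifluoromethoxy exchange on aryl urea

The compounds below may be only part of what the source reports. "The series", "measured", "known", "first", "only" and "open" are said of these compounds alone.

Measured so far in a functional assay on CRL2813 cells (Homo sapiens) for cytotoxicity, read by sulforhodamine B assay, with a stated time of 5 days; a lower number here means a stronger inhibitor, a higher number a weaker inhibitor:
compound 1, `O=C(Nc1ccc(I)cc1)N[C@H]1CC[C@H](Oc2ccc(F)cc2)CC1`, 10200 nM
compound 2, `O=C(Nc1cccc(F)c1)N[C@H]1CC[C@H](Oc2ccc(F)cc2)CC1`, 8300 nM
compound 3, `O=C(Nc1ccccc1[N+](=O)[O-])N[C@H]1CC[C@H](Oc2ccc(F)cc2)CC1`, 3500 nM

Compound 3 gives the lowest number of the three: the steps of a 2.9-fold lower number from compound 1 to compound 3 (0.46 log units; beyond the scatter) and a 2.4-fold lower number from compound 2 to compound 3 (0.38 log units; beyond the scatter) are both modest, while a 1.2-fold lower number from compound 1 to compound 2 (0.09 log units; within the scatter) stays within the scatter. Compound 4, `O=C(Nc1ccccc1OC(F)(F)F)N[C@H]1CC[C@H](Oc2ccc(F)cc2)CC1`, carries trifluoromethoxy in place of nitro on an aromatic carbon. Within the data shown here, no measured step exchanges one group for another at one place on the same aromatic ring; each measured step moves the substituent as well as replacing it, so none bears directly on this change. The two modest gains toward compound 3 set the scale; a step of similar size in either direction, or none beyond the scatter, is plausible. Compound 4 is therefore expected at 5000 nM (range 2000 nM to 12000 nM). The estimated step of a 1.4-fold higher number from compound 3 to compound 4 (0.15 log units; within the scatter) is within the scatter.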

Compound 4, half-maximal inhibitory concentration: > 20000 nM
Compound 4: only a limit was reported; the forecaster's own chance of this, stated with the estimate: 5%; middle value at least 4.0-fold (0.60 log units) from the limit.
By their numbers in this assay, from the lowest: compound 3; then compounds 2 and 1 (each within the scatter of the next). At a limit, above all of these: compound 4.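

Compound 4 is reported only as a limit of the assay, not as a number: the limit of > 20000 nM in this assay, at which 1 of the 4 values shown sits. On this aromatic carbon, ortho to a large group, trifluoromethoxy in place of nitro gives an at least 5.7-fold higher number from compound 3 to compound 4 (0.75 log units; beyond the scatter) in this assay. Among these compounds, this is the first step that keeps the place on the ring and changes only the group, and it exceeds every earlier step in size.

The compounds shown leave open whether nitro is favoured here or trifluoromethoxy is disfavoured. An amine or a carboxylic acid at this place would help separate the two.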